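A few compounds are considered here, and "the series" means these few. Any claim that something is new, unique, unknown or untested is made for them only; others in the source may bear on it.

Working notes on the series. In an assay on LX2 cells for inhibition of COL1A1 promoter (Homo sapiens), read by a luciferase reporter, with a stated time of 24 h, tested at 20 uM (on this read-out higher numbers stand for a stronger effect at the one concentration tested and lower numbers for a weaker effect), compound 1 `Cc1cc(OCCCCCCC[N+]23CCN(CC2)CC3)cc(-n2cc(C(=O)Nc3cc(F)cc(F)c3)c(=O)c3ccc(N(C)C)nc32)c1` gives 10.3%, the lowest of the two numbers in hand; its nearest neighbour is compound 2 `Cc1ccc(-n2cc(C(=O)Nc3cc(F)cc(F)c3)c(=O)c3ccc(N(C)C)nc32)cc1OCCCCCCC[n+]1ccccc1`, which in this assay gives 39.7%, a gap beyond the scatter. Going by the values given here, no single-point step between measured compounds is available, so these two values show only what their numbers say. Compound 3 `CC[N+]1(CCCCCCCOc2cc(C)cc(-n3cc(C(=O)Nc4cc(F)cc(F)c4)c(=O)c4ccc(N(C)C)nc43)c2)CCCC1` differs from compound 1 at the far end of the chain: a group of 7 heavy atoms (6 carbon, 1 nitrogen; one five-membered non-aromatic ring with 1 hetero atom) in place of a group of 8 heavy atoms (6 carbon, 2 nitrogen; 2 six-membered non-aromatic rings with 2 hetero atoms each), on a saturated chain carbon, seven bonds along the chain from an oxygen on an aromatic ring. Among the compounds with values here, with no measured step of this kind to lean on, the expectation rests on the low reading of compound 1 in this assay, 10.3%, and the higher one of compound 2; a small rise, at or about the usual scatter, is expected a number 9.7 percentage points higher from compound 1 to compound 3 (within the scatter). Compound 3 is accordingly estimated at 20% in this assay, with a range from 0% to 42%.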

Compound 3, a percentage reported as inhibition, at one concentration (the size of the read-out at that concentration, not a potency): 35.1%
The estimate for compound 3 lay 15.1 percentage points below the measured number; measured number inside the range.
By their numbers in this assay, from the lowest: compound 1; then compounds 3 and 2 (each within the scatter of the next).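

In this assay the far end of the chain is not indifferent to the group it carries: the change gives a number 24.8 percentage points higher from compound 1 to compound 3 (beyond the scatter) when the group of 7 heavy atoms (one five-membered non-aromatic ring with 1 hetero atom) replaces the group of 8 heavy atoms (2 six-membered non-aromatic rings with 2 hetero atoms each). Both groups carry a net charge of +1, so a charged group at this position does not by itself fix the read-out, although the two differ in hydrogen-bond acceptors, 1 leaving and 0 entering. Nothing at hand accounts for the step.

The compounds shown do not separate ring size from the loss of the second ring nitrogen. Going by these compounds, it also stays open how a trimethylammonium group, a carboxylic acid or a shorter chain would read at this position.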